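The source may hold more compounds than are shown below. What is called first, only, known or untested is meant among the compounds shown, and "the series" means these compounds.

Three compounds of this series have been examined in an ADME assay on HeLa cells (Homo sapiens) for cytotoxicity, read by ATP content, with a stated time of 3 days; on this read-out lower numbers stand for higher toxicity in this test and higher numbers for lower toxicity in this test. Compound 1 `O=c1n(Cc2nc3nc(Cl)ccc3n2CCCCF)c2cnccc2n1C1CC1` reaches only a limit of the test, giving > 50000 nM. Compound 3 `CC(C)CCn1c(Cn2c(=O)n(C3CC3)c3ccncc32)cc2ccccc21` likewise reports a limit, > 100000 nM. Compound 2 `CS(=O)(=O)c1ccc(-n2c(=O)n(Cc3cc4cc(Cl)ccc4n3CCCC#N)c3cnccc32)cc1` stands at a limit as well, with > 50000 nM. None of the three therefore yields a number: one value sits at the limit of > 100000 nM in this assay, at which 1 of the 3 values shown sits, and two sit at the limit of > 50000 nM in this assay, at which 2 of the 3 values shown sit, and compound 2 belongs to the latter pair, so its standing cannot be placed above or below the others on these figures alone. The unmeasured compound 4 `N#CCCCn1c(Cn2c(=O)n(-c3ccc(OC(F)(F)F)cc3)c3ccncc32)cc2cc(Cl)ccc21` differs from compound 2 in a single place: trifluoromethoxy in place of methylsulfonyl on an aromatic carbon. Among the compounds with values here, no step between two measured compounds is available, so there is no measured guide to how large such a change may be. Given that every value so far rests at a limit, the step that the limit leaves unreadable from compound 2 to compound 4 is expected to be none beyond the scatter. Compound 4 is accordingly estimated to give 60000 nM in this assay, with a range from 20000 nM to 150000 nM.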

Compound 4, half-maximal cytotoxic concentration: > 50000 nM
Compound 4: a limit, no number; the forecaster's own chance of this, stated with the estimate: 75%; the middle value does not contradict the limit.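

Compound 2 and compound 4 both stand at a limit of this assay, and the step between them cannot be read. The compounds shown leave open whether trifluoromethoxy in place of methylsulfonyl changes the read-out at all, and at what concentration any of them becomes toxic.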